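Methoxy to hydroxy on an aromatic ring: series notes

The source may hold more compounds than are shown below. What is called first, only, known or untested is meant among the compounds shown, and "the series" means these compounds.

Measured so far:
compound 1 `COc1cccc(/C=C/C(=O)c2ccc(OC)c3c2OC(C)(C)C=C3)c1`, in a functional assay on SW-620 cells (Homo sapiens) for antiproliferative activity, read by MTT assay, with a stated time of 24 h (a lower number here means a stronger inhibitor, a higher number a weaker inhibitor), a limit only: > 10000 nM
compound 2 `COc1ccc(C(=O)/C=C/c2cc(OC)c(OC)c(OC)c2)c2c1C=CC(C)(C)O2`, in this assay: 9150 nM
compound 3 `COc1ccc(C(=O)/C=C/c2cccc(O)c2)c2c1C=CC(C)(C)O2`, in this assay a limit only: > 10000 nM

Compound 1 and compound 3 differ by hydrogen in place of methyl on an oxygen on an aromatic ring. The step that the two limits leave unreadable from compound 1 to compound 3 cannot be read because of the limit of > 10000 nM in this assay, at which 2 of the 3 values shown sit. Compound 2 and compound 1 differ in more than one place; the difference between the two cores is not broken down here. Compound 4 `COc1cc(/C=C/C(=O)c2ccc(OC)c3c2OC(C)(C)C=C3)cc(OC)c1O` stands to compound 2 as compound 3 stands to compound 1, differing by hydrogen in place of methyl on an oxygen on an aromatic ring, the same change at the same place. The earlier step gives no size to lean on. The expectation for compound 4 rests on the value of compound 2 in this assay, 9150 nM. Compound 4 is estimated at 12000 nM, within 4000 nM to 40000 nM. The expected step of a 1.3-fold higher number from compound 2 to compound 4 (0.12 log units; within the scatter) is small, and a limit rather than a number is likely.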

Compound 4, half-maximal inhibitory concentration: > 10000 nM
Compound 4 gave a limit, no number; the forecaster's own chance of this, stated with the estimate: 55%; the middle value does not contradict the limit.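

Carried to the core of compound 2, hydrogen in place of methyl on an oxygen on an aromatic ring gives an at least 1.0-fold higher number from compound 2 to compound 4 (0.03 log units; that floor lies within the scatter) in this assay. Compound 4 gives only a limit, > 10000 nM, so this step is a floor and not a size, and the matching steps on the two cores cannot be compared. The data show no stronger compound after the change on either core, but whether the change carries over in the same way cannot be judged because the values crowd at one limit: the limit of > 10000 nM in this assay, at which 3 of the 4 values shown sit.

Still open, on these data alone, is whether a longer chain on that oxygen, or an amine or a carboxylic acid at the end of such a chain, would give a number in this assay. With only one number among the compounds shown, the series offers no measured step of known size for this change.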